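The compounds below may be only part of what the source reports. "The series", "measured", "known", "first", "only" and "open" are said of these compounds alone.

Compound 1 `Oc1ccccc1/C=N\NC(=S)N(Cc1ccccc1)Cc1ccccc1` is the starting point of this comparison. In an ADME assay on Vero cells (Chlorocebus sabaeus) for cytotoxicity, read by MTT assay, with a stated time of 72 h (a lower number here means that less compound is tolerated, a higher number that more compound is tolerated), compound 1 gives 166000 nM, which is the lowest of the two numbers reported here. Compound 2 `C=CCN(CC=C)C(=S)N/N=C(/C)c1ccc(O)cc1` gives 216000 nM in this assay, and the gap between compound 2 and compound 1 sits within the scatter of repeated measurements, so the two cannot be ranked against each other. Among the compounds with values here, compound 3 `C=CCN(CC=C)C(=S)N/N=C\c1ccc([N+](=O)[O-])o1` is reported in this assay only as a limit of < 213000 nM, not as a number; it is the one value sitting at the limit of < 213000 nM in this assay, at which 1 of the 3 values shown sits.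

Compound 4 `O=[N+]([O-])c1ccc(/C=N\NC(=S)N(Cc2ccccc2)Cc2ccccc2)o1` has not yet been measured in this assay. It differs from compound 1 by one change: 5-nitrofuran-2-yl in place of 2-hydroxyphenyl on a carbon with a double bond to nitrogen. The same 5-nitrofuran-2-yl group is carried by compound 3, whose reading in this assay is a limit. Within the data shown here, no measured pair here isolates this change, so the size of the step is open. The step from compound 1 to compound 4 is expected to be a 1.4-fold lower number from compound 1 to compound 4 (0.14 log units; within the scatter). Compound 4 is therefore estimated at 120000 nM, within a range from 40000 nM to 300000 nM, and a reading reported only as a limit is considered a real possibility.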

Compound 4, half-maximal cytotoxic concentration: 158000 nM
For compound 4 the middle estimate is 1.3-fold (0.12 log units) below the measured one; the measured number falls inside the stated range.
By their numbers in this assay, from the lowest: compounds 4, 1 and 2 (each within the scatter of the next).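

In this assay, placing 5-nitrofuran-2-yl in place of 2-hydroxyphenyl on a carbon with a double bond to nitrogen gives a 1.1-fold lower number from compound 1 to compound 4 (0.02 log units; within the scatter). Within the data shown here, this is the first measured pair to isolate this change, and it shows that the two compounds cannot be told apart in this assay, although the two groups differ in ring size and in their hydrogen-bond donors and acceptors. Compound 3, which carries the same 5-nitrofuran-2-yl group, remains a limit and not a number: the limit of < 213000 nM in this assay, at which 1 of the 4 values shown sits.

The compounds shown leave open whether an amine or a carboxylic acid in this place would also stay within the scatter of compound 1. They also leave open whether the same change would read alike on a core other than that of compound 1.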